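This account rests on a few compounds, and the source may have more. Where it says the series, first, only, none or still open, it means among the compounds named here.

Measured in an ADME assay on S9 fraction from liver (Homo sapiens) for metabolic stability, with a stated time of 1 h; a lower number here means that less of the compound is left, a higher number that more of the compound is left:
- compound 1 `N#Cc1cnc(NCc2cnccc2C(F)(F)F)cc1N[C@H]1C[C@@H](O)C1`: 90%
- compound 2 `CO[C@H]1CC[C@@H](Nc2cc(NCc3cnccc3C(F)(F)F)ncc2C#N)CC1`: 19%

Of the two measured compounds, compound 2 stands lowest at 19%, well under compound 1. Compound 3 `N#Cc1cnc(NCc2cnccc2C(F)(F)F)cc1N[C@H]1CC[C@@H](n2cncn2)CC1` differs from it on a saturated ring carbon: 1H-1,2,4-triazol-1-yl in place of methoxy on a saturated ring carbon. Among the compounds with values here, the only measured step, a number 71 percentage points lower from compound 1 to compound 2 (beyond the scatter), is large, but it is a different change. Within the data shown here, it shows only that the number can move widely, and no measured step tests this replacement directly. A moderate rise is therefore expected, with a number 16 percentage points higher from compound 2 to compound 3 (beyond the scatter) as the estimated step. For compound 3 the estimate in this assay is 35%, expected to lie between 12% and 65%.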

Compound 3, percent of the compound remaining: 64%
The estimate for compound 3 lay 29 percentage points below the measured number; the measured number falls inside the stated range.
By their numbers in this assay, from the lowest: compound 2; then compound 3; then compound 1.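

With the six-membered ring of carbon kept, 1H-1,2,4-triazol-1-yl in place of methoxy gives a number 45 percentage points higher from compound 2 to compound 3 (beyond the scatter) in this assay, so the group on this saturated ring carbon can alone move the number widely. The earlier step changed the ring and its group together and could not show this. Nothing available here accounts for the rise. Going by these compounds, whether an amine, a carboxylic acid or a longer ether chain on this carbon would move the number as far remains open. So does whether 1H-1,2,4-triazol-1-yl would have a comparable effect in place of the hydroxy group of compound 1.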